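The source may report more compounds than this note shows. Statements on the series, on what has been measured and on what is new or still open speak of the compounds shown alone.

Measured in a functional assay on U-373MG ATCC cells (Homo sapiens) for inhibition, read by colorimetric assay and MTT assay, with a stated time of 72 h; on this read-out higher numbers stand for weaker inhibition and lower numbers for stronger inhibition:
- compound 1 `C=CCCCCOc1ccccc1-c1cnc(OCCC=C)n1C`: 33000 nM
- compound 2 `C=CCCCCOc1ccccc1-c1cnc(OCCCC=C)n1C`: 5000 nM
- compound 3 `C=CCCCCOc1ccccc1-c1cnc(OCCCCC=C)n1C`: 7000 nM

Compound 3 belongs to the stronger end of this small set. The a 4.7-fold lower number from compound 1 to compound 3 (0.67 log units; beyond the scatter) is beyond the scatter, while a 1.4-fold higher number from compound 2 to compound 3 (0.15 log units; within the scatter) is within it.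

Compound 4 `C=CCCCCCOc1ncc(-c2ccccc2OCCCCC=C)n1C` lengthens the same chain again: allyl in place of vinyl on a saturated chain carbon, four bonds along the chain from an oxygen on an aromatic ring. Two measured steps made this kind of change nearer the oxygen. The a 6.6-fold lower number from compound 1 to compound 2 (0.82 log units; beyond the scatter) was beyond the scatter, but a 1.4-fold higher number from compound 2 to compound 3 (0.15 log units; within the scatter) was not, and that closer precedent suggests little further movement in this assay. The expected result is a 1.2-fold lower number from compound 3 to compound 4 (0.07 log units; within the scatter), which would lie within the scatter. For compound 4 the estimate is 6000 nM, with an expected range of 2500 nM to 16000 nM.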

Compound 4, half-maximal inhibitory concentration: 76000 nM
Compound 4: middle estimate off by 13-fold (1.10 log units), on the low side, and the stated range ends below it.
By their numbers in this assay, from the lowest: compounds 2 and 3 (each within the scatter of the next); then compound 1; then compound 4.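

Adding one more carbon at this place, four bonds along the chain from an oxygen on an aromatic ring, is not harmless: it gives an 11-fold higher number from compound 3 to compound 4 (1.04 log units; beyond the scatter). Against the two shorter chains the result reads a 15-fold higher number from compound 2 to compound 4 (1.18 log units; beyond the scatter) and a 2.3-fold higher number from compound 1 to compound 4 (0.36 log units; beyond the scatter), so lengthening helps only up to a point in this series. The same change can therefore push the number either way, depending on the chain it starts from: the same change on two cores in this assay, a 6.6-fold lower number (0.82 log units; beyond the scatter) from compound 1 to compound 2 and an 11-fold higher number (1.04 log units; beyond the scatter) from compound 3 to compound 4, 72-fold (1.86 log units) apart, beyond the scatter of two such steps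

Still open, on these data alone, is whether a longer chain would raise the number further. Also open, as far as these compounds go, is whether a saturated hexyl end would behave like the alkene.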